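The compounds below may be only part of what the source reports. "The series", "measured", "known", "first", "only" and "open" are said of these compounds alone.

In a physicochemical assay for lipophilicity, at pH 7.4 (on this read-out lower numbers stand for lower lipophilicity and higher numbers for higher lipophilicity), the measured compounds stand as follows:

Compound 1 `Cc1ccc(N(CC(C)C)S(=O)(=O)c2ccc3c(c2)C(=O)CC(C2CCOCC2)O3)c(C)c1` gives 4.28
Compound 2 `CC(C)CN(c1cc2ccccc2s1)S(=O)(=O)c1ccc2c(c1)C(=O)CC(C1CCOCC1)O2` gives 4.01
Compound 3 `CC(C)CN(c1ccccc1F)S(=O)(=O)c1ccc2c(c1)C(=O)CC(C1CCOCC1)O2` gives 3.44

Compound 3 holds the lowest of the three numbers, and both others lie above it by more than the scatter. Compound 4 `CC(C)CN(c1ccc(F)cc1)S(=O)(=O)c1ccc2c(c1)C(=O)CC(C1CCOCC1)O2` differs from it in one place (4-fluorophenyl in place of 2-fluorophenyl on a sulfonamide nitrogen). There, 4-fluorophenyl stands in place of 2-fluorophenyl on a sulfonamide nitrogen, and the two compounds have the same atoms, joined differently. Among the measured compounds shown here, three measured steps concern that nitrogen: a number 0.27 log units lower from compound 1 to compound 2 (within the scatter) and a number 0.84 log units lower from compound 1 to compound 3 (beyond the scatter) and a number 0.57 log units lower from compound 2 to compound 3 (beyond the scatter) are each an exchange of one whole group for a different one. None of them shifts the fluorine alone, so they offer only a loose guide. The change here is smaller in kind than the exchanges in the steps of a number 0.84 log units lower from compound 1 to compound 3 (beyond the scatter) and a number 0.57 log units lower from compound 2 to compound 3 (beyond the scatter), so a shift beyond the scatter is not expected, and a number 0.06 log units higher from compound 3 to compound 4 (within the scatter) is the expected step in this assay for now. For compound 4 the estimated value is 3.5, with an expected range from 3.1 to 3.9.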

Compound 4, distribution coefficient: 3.48
The estimate for compound 4 lay 0.02 log units above the measured number; the range from low to high includes it.
By their numbers in this assay, from the lowest: compounds 3 and 4 (each within the scatter of the next); then compounds 2 and 1 (each within the scatter of the next).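

In this assay, among the compounds shown here, 4-fluorophenyl in place of 2-fluorophenyl on the sulfonamide nitrogen gives a number 0.04 log units higher from compound 3 to compound 4 (within the scatter), the first step here in which the same atoms are only joined differently, and on this read-out the two fluorophenyl compounds cannot be told apart. The exchanges of whole groups read much the same from the new compound, with a number 0.53 log units lower from compound 2 to compound 4 (beyond the scatter) and a number 0.80 log units lower from compound 1 to compound 4 (beyond the scatter), so the separation seen with the 2-fluorophenyl group also holds for the 4-fluorophenyl group. No measurement at hand bears on the reason for this result.

The compounds shown leave open whether the place of a group on the phenyl ring would count as little with a methoxy group or a nitrile instead of fluorine. They also leave open how an amine or a carboxylic acid on that ring would stand in this assay.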